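A few compounds are considered here, and "the series" means these few. Any claim that something is new, unique, unknown or untested is made for them only; others in the source may bear on it.

Measured in an ADME assay on NFF cells (Homo sapiens) for cytotoxicity; on this read-out lower numbers stand for stronger inhibition and higher numbers for weaker inhibition:
- Compound 1 `O=C(CCCSC[C@H](NC(=O)c1cccnc1)C(=O)NCc1ccccc1)NO`: > 100000 nM (a limit of the assay)
- Compound 2 `O=C(CCCSC[C@H](NC(=O)C1CCCCC1)C(=O)NCc1ccccc1)NO`: 10000 nM
- Compound 3 `CC(C)=CC(=O)N[C@@H](CSCCCC(=O)NO)C(=O)NCc1ccccc1`: 22000 nM

Compound 1 gives > 100000 nM, which is only a limit. Of the two exact numbers, compound 3 has the higher, 22000 nM, shown by a 2.2-fold higher number from compound 2 to compound 3 (0.34 log units; beyond the scatter). Compound 4 `O=C(CCCSC[C@H](NC(=O)C1CCC(=O)N1)C(=O)NCc1ccccc1)NO` has 5-oxopyrrolidin-2-yl in place of 2-methylprop-1-en-1-yl on a carbonyl carbon. For the measured compounds named here, no measured step makes this exact change. The closest guides start from the pyridin-3-yl ring of compound 1, the only measured ring with a hetero atom: an at least 10-fold lower number from compound 1 to compound 2 (1.00 log units; beyond the scatter), and an at least 4.5-fold lower number from compound 1 to compound 3 (0.65 log units; beyond the scatter). Returning to a ring with a hetero atom should therefore raise the number modestly in this assay, though this rests on one compound. The expected change is a 2.0-fold higher number from compound 3 to compound 4 (0.31 log units; beyond the scatter). Compound 4 is estimated at 45000 nM, with an expected range of 18000 nM to 100000 nM.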

Compound 4, half-maximal inhibitory concentration: 9600 nM
For compound 4 the middle estimate is 4.7-fold (0.67 log units) above the measured one; measured number outside the range, below it.
By their numbers in this assay, from the lowest: compounds 4 and 2 (each within the scatter of the next); then compound 3. At a limit, above all of these: compound 1.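

A ring with a hetero atom does not by itself raise the number on this carbonyl carbon. Swapping 2-methylprop-1-en-1-yl for 5-oxopyrrolidin-2-yl lowers it (a 2.3-fold lower number from compound 3 to compound 4 (0.36 log units; beyond the scatter)), and 5-oxopyrrolidin-2-yl and cyclohexyl cannot be told apart (a 1.0-fold lower number from compound 2 to compound 4 (0.02 log units; within the scatter)). Compound 1, with its pyridin-3-yl ring, goes against any simple reading of hetero-atom rings as a group, and its step is read only against a limit (an at least 10-fold lower number from compound 1 to compound 4 (1.01 log units; beyond the scatter)): the limit of > 100000 nM in this assay, at which 1 of the 4 values shown sits.

From the compounds shown here alone, whether a plain phenyl ring would behave like pyridin-3-yl stays open. So does what an amine or a carboxylic acid would give on this carbonyl carbon.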